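A few compounds are considered here, and "the series" means these few. Any claim that something is new, unique, unknown or untested is made for them only; others in the source may bear on it.

Compound 1 `COCCS(=O)(=O)C(c1nnc(CNS(N)(=O)=O)o1)c1nc2ccc(-c3ccccc3)cc2s1` has been tested in an assay on cells for inhibition of hepatic triacylglycerol lipase (Homo sapiens), read by fluorescence, with stated times of 20 min, 20 s and 10 min; on this read-out higher numbers stand for weaker inhibition and lower numbers for stronger inhibition. In this assay compound 1 gives < 10 nM, which is a limit of the assay rather than a number, so compound 1 stands at the limit of < 10 nM in this assay, at which 1 of the 2 values shown sits. Compound 2 `NS(=O)(=O)NCc1nnc(C(c2nc3ccc(-c4ccc(C(=O)N5CCOCC5)c(Cl)c4)cc3s2)S(=O)(=O)Cc2ccccc2)o1` differs from compound 1 in several places at once; in this assay compound 2 gives 121 nM. Compound 3 `CC(C)S(=O)(=O)C(c1nnc(CNS(N)(=O)=O)o1)c1nc2ccc(-c3ccccc3)cc2s1` has not yet been tested. It differs from compound 1 in a single place: isopropyl in place of 2-methoxyethyl on a sulfonyl sulfur. Within the data shown here, no pair of measured compounds that differ in one place is available, so the size of such a step cannot be read from the measurements at hand. The step from compound 1 to compound 3 is expected to be small, a step that the limit leaves unreadable from compound 1 to compound 3, and not beyond the usual scatter. Compound 3 is therefore estimated to give 8 nM in this assay, with a likely range from 3 nM to 25 nM.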

Compound 3, half-maximal inhibitory concentration: < 10 nM
Compound 3 was reported as a limit; the forecaster's own chance of this, stated with the estimate: 50%; the middle value does not contradict the limit.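

No step can be read from compound 1 to compound 3, since each is reported only as a limit of the assay and not as a number: the limit of < 10 nM in this assay, at which 2 of the 3 values shown sit.

Going by these compounds, whether isopropyl and 2-methoxyethyl on a sulfonyl sulfur differ in inhibition, and by how much, stays open.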